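Methoxy-to-hydroxy steps in a benzofuran ketone series

The compounds below may be only part of what the source reports. "The series", "measured", "known", "first", "only" and "open" are said of these compounds alone.

Measured so far:
Compound 1 `CCc1oc2cc(OC)ccc2c1C(=O)c1ccc(OC)cc1` gives 6.2% in an assay for inhibition of solute carrier family 22 member 12 (Homo sapiens), read by scintillation counting, with a stated time of 60 min, tested at 50 uM; on this read-out higher numbers stand for more inhibition at the one concentration tested (going by the name of the read-out) and lower numbers for less inhibition.
Compound 2 `CCc1oc2cc(O)ccc2c1C(=O)c1ccc(OC)cc1` gives 48.3%.
Compound 3 `CCc1cc2c(C(=O)c3ccc(OC)cc3)cc(O)cc2o1` gives 12.4%.

Among the measured compounds shown here, the only single-point step measured so far is a number 42.1 percentage points higher from compound 1 to compound 2 (beyond the scatter); the change there is hydrogen in place of methyl on an oxygen on an aromatic ring. Compound 3 carries a different core, and how the cores of compound 1 and compound 3 differ is not broken down here. The values of compound 1 and compound 3 lie within the scatter of each other, so nothing is said about their order.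

Compound 4 `CCc1cc2c(C(=O)c3ccc(O)cc3)cc(O)cc2o1` is not yet measured and differs from compound 3 by hydrogen in place of methyl on an oxygen on an aromatic ring. The place reads the same word for word as for the earlier step, so this is the same change, now made on the core of compound 3, and it rests on a single precedent.

For the measured compounds named here, the expected step is a number 29.6 percentage points higher from compound 3 to compound 4 (beyond the scatter), estimated from the one precedent a number 42.1 percentage points higher from compound 1 to compound 2 (beyond the scatter). Compound 4 is therefore expected to fall near 42%, with a range from 15% to 65% that allows for the step not carrying over fully to a second core.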

Compound 4, a percentage reported as inhibition, at one concentration (the size of the read-out at that concentration, not a potency): 41%
Compound 4: middle estimate off by 1 percentage points, on the high side, within the range that was stated.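

In this assay, hydrogen in place of methyl on an oxygen on an aromatic ring gives a number 28.6 percentage points higher from compound 3 to compound 4 (beyond the scatter), so on the core of compound 3 the change points the same way as on the core of compound 1. This rests on one pair for each of two cores, so it shows no general rule for the series and says nothing about cores outside these compounds, and the data give no reason for the rise. The size of the step cannot be said to depend on the core, as the two steps do not separate: the same change on two cores in this assay, a number 42.1 percentage points higher (beyond the scatter) from compound 1 to compound 2 and a number 28.6 percentage points higher (beyond the scatter) from compound 3 to compound 4, 13.5 percentage points apart, within the scatter of two such steps

Still open, from the compounds shown here alone, is how an amine or a carboxylic acid in place of the hydroxy would read in this assay on either core. Also open, going by these compounds, is whether a longer chain on the oxygen, in place of methyl, would read like the methoxy compounds or fall somewhere between them and the hydroxy compounds.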